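Removing the Ester from the Triazole of Compound 2

The source may report more compounds than this note shows. Statements on the series, on what has been measured and on what is new or still open speak of the compounds shown alone.

Going by the values given here, in a functional assay (aorta) with Rattus norvegicus as the target (a lower number here means a stronger inhibitor, a higher number a weaker inhibitor), compound 2 `CCOC(=O)c1cn(CCOCC2=NC(C)=C(C(=O)OC)C(c3ccccc3Cl)/C2=C(\O)OCC)nn1` gives 50.1 nM, the lowest of the two numbers measured so far. Among the compounds with values here, its only comparator is compound 1 `CCO/C(O)=C1\C(COCCn2c(N)cnc2O)=NC(C)=C(C(=O)OC)C1c1ccccc1Cl`, which in this assay gives 158 nM. Within the data shown here, the single measured step, a 3.2-fold lower number from compound 1 to compound 2 (0.50 log units; beyond the scatter), exchanged one five-membered ring for another: 4-(ethoxycarbonyl)-1H-1,2,3-triazol-1-yl in place of 5-amino-2-hydroxy-1H-imidazol-1-yl, a change of the whole ring rather than of one group on it.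

Compound 3 `CCO/C(O)=C1\C(COCCn2ccnn2)=NC(C)=C(C(=O)OC)C1c1ccccc1Cl` keeps the triazole ring of compound 2 and drops only its ester: hydrogen in place of ethoxycarbonyl on an aromatic carbon. Among the measured compounds shown here, no measured step isolates this group, so the one step in hand bears on it only loosely; it shows that the ring region tolerates change of this size within about a modest span. Since the ethoxycarbonyl group was part of what set compound 2 apart in this assay, a small loss toward compound 1 is expected, though a number within the scatter of compound 2 would not surprise. Compound 3 is estimated at 100 nM, with a range from 30 nM to 320 nM, meaning an expected step of a 2.0-fold higher number from compound 2 to compound 3 (0.30 log units; within the scatter).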

Compound 3, half-maximal inhibitory concentration: 15.9 nM
Estimate against measurement, compound 3: 6.3-fold (0.80 log units) above, and the stated range ends above it.
By their numbers in this assay, from the lowest: compound 3; then compound 2; then compound 1.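

In this assay the ethoxycarbonyl group proves unnecessary for a low number: with hydrogen on that aromatic carbon of the triazole, the result is a 3.2-fold lower number from compound 2 to compound 3 (0.50 log units; beyond the scatter), so removing these five heavy atoms helps rather than harms. It also changes how the ring exchange reads, since the unsubstituted 1H-1,2,3-triazol-1-yl gives a 9.9-fold lower number from compound 1 to compound 3 (1.00 log units; beyond the scatter), a larger step than a 3.2-fold lower number from compound 1 to compound 2 (0.50 log units; beyond the scatter) seen with the ester-bearing ring, and compound 3 now has the lowest number of the three. No measurement available here accounts for this gain.

Hydrogen and ethoxycarbonyl are the only two groups compared on this carbon. The result is a single pair and not a trend, and it cannot say whether any group at all is worse than hydrogen. A methyl group, a hydroxymethyl group, a carboxylic acid or a primary amide in the same place would show whether size alone tracks with the number or whether the ester itself is the particular liability.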